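Stereochemistry and halogen swap in an aryl urea series

This account rests on a few compounds, and the source may have more. Where it says the series, first, only, none or still open, it means among the compounds named here.

Measured compounds:
- Compound 1, `C[C@@H](NC(=O)Nc1ccccc1C(F)(F)F)c1ccccc1`: 54%
- Compound 2, `C[C@H](NC(=O)Nc1ccccc1C(F)(F)F)c1ccccc1`: 97%
- Compound 3, `COc1cccc(NC(=O)N[C@@H](C)c2ccccc2)c1`: 99%

In an ADME assay on the whole organism with Oryza sativa as the target, tested at 10 uM (a lower number here means a stronger effect, a higher number a weaker effect of the compound at the concentration tested), compound 1 gives the lowest of the three numbers, the strongest effect in this set. The nearest is compound 2, with a number 43 percentage points higher from compound 1 to compound 2 (beyond the scatter); compound 3 lies further off. Because (the fact that compounds 1 and 2 differ only in the configuration as drawn), the step between compound 1 and compound 2 turns on configuration alone.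

Compound 4, `C[C@@H](NC(=O)Nc1ccccc1Cl)c1ccccc1`, is not yet measured. It differs from compound 1 by chloro in place of trifluoromethyl on an aromatic carbon, the change sitting on an aromatic carbon of a six-membered aromatic ring of carbon only. No measured step touches this exchange: the only step shown, from compound 1 to compound 2, changes configuration and not the substituent, and compound 3 differs from compound 1 in more than one place, so its value alone says little here. The expectation is therefore a modest weakening at most, with wide uncertainty.

Compound 4 is estimated at 65% in this assay, within 35% to 95%, meaning an expected step of a number 11 percentage points higher from compound 1 to compound 4 (beyond the scatter).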

Compound 4, a percentage reported as activity, at one concentration (the size of the read-out at that concentration, not a potency): 93%
Compound 4: the middle estimate sits 28 percentage points below what was measured; measured number inside the range.
By their numbers in this assay, from the lowest: compound 1; then compounds 4, 2 and 3 (each within the scatter of the next).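

In this assay, chloro in place of trifluoromethyl on this aromatic carbon, ortho to a large group, gives a number 39 percentage points higher from compound 1 to compound 4 (beyond the scatter) and so counts as a large step. Earlier, a number 43 percentage points higher from compound 1 to compound 2 (beyond the scatter) tied the stronger effect of compound 1 to configuration alone; the new step ties it to the trifluoromethyl group as well, so among these compounds the effect needs both features together. Going by these compounds alone, nothing at hand explains why this exchange moves the number so far.

Open, going by these compounds, is whether bromo, methyl or a nitrile on this aromatic carbon would leave the number near that of compound 1 or near that of compound 4. Also open, on these data alone, is whether configuration matters at all once chloro replaces trifluoromethyl.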